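This account rests on a few compounds, and the source may have more. Where it says the series, first, only, none or still open, it means among the compounds named here.

Of the compounds shown here, three from one series have been tested in a functional assay on HT-29 cells (Homo sapiens) for cytotoxicity, read by MTT assay, with a stated time of 72 h; a lower number here means a stronger inhibitor, a higher number a weaker inhibitor. Compound 1, with the structure `CN(C)CCCNc1nc(-c2ccc(NC(=O)Nc3ccc(Cl)cc3Cl)cc2)nc2c(Cl)c(Cl)sc12`, gives 1320 nM in this assay. Compound 2, with the structure `Cc1ccc(NC(=O)Nc2ccc(-c3nc(NCCCN(C)C)c4sc(Cl)c(Cl)c4n3)cc2)cc1`, gives 1320 nM in this assay. These two are built on the same core and differ only in one part: 4-methylphenyl in place of 2,4-dichlorophenyl on an amide-type nitrogen. The step of no change at the digits printed from compound 1 to compound 2 (within the scatter) shows this exchange leaving the result where it was.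

Compound 3, with the structure `CN(C)CCNc1nc(-c2ccc(NC(=O)Nc3ccc(Cl)cc3Cl)cc2)nc2ccsc12`, gives 1320 nM in this assay, level with compound 1 and compound 2. Compound 3 carries the same 2,4-dichlorophenyl group as compound 1 but sits on a different core; how the two cores differ is not broken down here.

Compound 4, with the structure `Cc1ccc(NC(=O)Nc2ccc(-c3nc(NCCN(C)C)c4sccc4n3)cc2)cc1`, has not yet been measured. It stands to compound 3 as compound 2 stands to compound 1: 4-methylphenyl in place of 2,4-dichlorophenyl on an amide-type nitrogen. The place of the change is described in the same words in both pairs, an amide-type nitrogen whose other neighbour is a carbonyl carbon, so this is the same change made on the core of compound 3.

The step of no change at the digits printed from compound 3 to compound 4 (within the scatter) is expected to be as small as the earlier one, because no change at the digits printed from compound 1 to compound 2 (within the scatter) showed no movement for the identical exchange. On that basis compound 4 is estimated at 1320 nM in this assay, with a range from 600 nM to 2900 nM expected to hold most repeat measurements.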

Compound 4, half-maximal inhibitory concentration: 2150 nM
Compound 4: the middle estimate sits 1.6-fold (0.21 log units) below what was measured, within the range that was stated.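

In this assay, putting 4-methylphenyl in place of 2,4-dichlorophenyl on an amide-type nitrogen of the core of compound 3 gives a 1.6-fold higher number from compound 3 to compound 4 (0.21 log units; within the scatter), so this exchange does not move the result beyond what repeat measurements would be expected to show. The same exchange was also made on the core of compound 1, and the two steps agree, which means that in this series the result of the exchange carries over from one of these cores to the other: the same change on two cores in this assay, no change at the digits printed (within the scatter) from compound 1 to compound 2 and a 1.6-fold higher number (0.21 log units; within the scatter) from compound 3 to compound 4, 1.6-fold (0.21 log units) apart, within the scatter of two such steps. This does not show that the exchange would behave alike on any further core, and since neither step rises above the scatter, the agreement is between two results that show no clear effect, so it cannot show that a change with a clear effect would carry across in the same way.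

The compounds shown leave open whether a different group on that amide-type nitrogen, such as a cyclohexyl ring or a phenyl ring carrying a carboxylic acid or an amine, would shift the result on either core. They also leave open whether the two cores would still agree for such a group.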